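Carboxymethyl in place of carboxy on the shared core

The source may report more compounds than this note shows. Statements on the series, on what has been measured and on what is new or still open speak of the compounds shown alone.

Measured compounds:
compound 1, `COC(=O)c1ccc(OCc2oc(-c3ccccc3OC)nc2C)cc1`: 17900 nM
compound 2, `COc1ccccc1-c1nc(C)c(COc2ccc(C(=O)O)cc2)o1`: > 80000 nM

In an assay on cells for antagonist activity at vitamin D3 receptor (Homo sapiens), read by a luciferase reporter (on this read-out higher numbers stand for weaker inhibition and lower numbers for stronger inhibition), compound 1 gives 17900 nM. For compound 2 this assay reports only a limit, > 80000 nM. Going by the values given here, the single measured step, an at least 4.4-fold higher number from compound 1 to compound 2 (0.65 log units; beyond the scatter), therefore ends at the limit of > 80000 nM in this assay, at which 1 of the 2 values shown sits, and compound 2 stands at that limit rather than at a number: of the two compounds, it is the one for which no value inside the measured range is known.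

Compound 3, `COc1ccccc1-c1nc(C)c(COc2ccc(CC(=O)O)cc2)o1`, differs from compound 2 in one place: carboxymethyl in place of carboxy on an aromatic carbon. Among the compounds with values here, no measured step covers this exchange. Within the data shown here, the only step on record, an at least 4.4-fold higher number from compound 1 to compound 2 (0.65 log units; beyond the scatter), concerns a different change and itself runs into the limit, so it gives no size for what the carboxymethyl group should do. With compound 2 already at the limit, any further weakening would not appear as a number, and a gain would have to be large to do so.

Compound 3 is therefore expected to sit near the limit as well, estimated at 100000 nM with a range of 30000 nM to 300000 nM. The step that the limit leaves unreadable from compound 2 to compound 3 is expected to stay within the scatter.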

Compound 3, half-maximal inhibitory concentration: > 80000 nM
Compound 3 gave a limit, no number; the forecaster's own chance of this, stated with the estimate: 75%; the middle value lies beyond the limit too.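

In this assay compound 3 gives > 80000 nM, which is a limit and not a number, and the step from carboxy to carboxymethyl at this position cannot be read: the limit of > 80000 nM in this assay, at which 2 of the 3 values shown sit.

Carboxymethyl in place of methoxycarbonyl on the same aromatic carbon gives an at least 4.4-fold higher number from compound 1 to compound 3 (0.65 log units; beyond the scatter), which makes it the second exchange of the methoxycarbonyl group to end at the limit, after an at least 4.4-fold higher number from compound 1 to compound 2 (0.65 log units; beyond the scatter). Among the three compounds, only the one carrying methoxycarbonyl has a value inside the measured range, and carboxymethyl in place of carboxy did not bring a number back.

On these data alone, how far compound 2 and compound 3 actually lie apart stays open, as does how far either lies from compound 1 beyond the stated minimum. Also open, as far as these compounds go, is what a methyl ester on the carboxymethyl chain, an ethyl ester or a primary amide at this place would give in this assay, and so whether the ester itself or something else about compound 1 goes with a measurable number.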